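Switching the chain on the shared core of compound 3

The compounds below may be only part of what the source reports. "The series", "measured", "known", "first", "only" and "open" are said of these compounds alone.

Measured compounds:
- compound 1, `CCCn1cnc2c(NC(=N)N)nc(N)nc21`, 36500 nM
- compound 2, `N=C(N)Nc1nc(N)nc2c1ncn2CCO`, > 100000 nM
- compound 3, `CC(C)n1cnc2c(NC(=N)N)nc(NCCCO)nc21`, 8800 nM

Of the compounds shown here, three sharing one core have been tested in a functional assay on MCF7 cells (Homo sapiens) for inhibition, read by fluorescence, with a stated time of 72 h; on this read-out lower numbers stand for stronger inhibition and higher numbers for weaker inhibition. Compound 1 gives 36500 nM. For compound 2 the assay reports only a limit, > 100000 nM, which is the limit of > 100000 nM in this assay, at which 1 of the 3 values shown sits. Compound 3 gives 8800 nM, the lowest of the two numbers that are not limits; the other number, that of compound 1, is higher.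

Within the data shown here, the only measured step between neighbours is an at least 2.7-fold higher number from compound 1 to compound 2 (0.43 log units; beyond the scatter). It concerns the chain on the aromatic nitrogen, not the position that changes next.

Compound 4, `CC(C)n1cnc2c(NC(=N)N)nc(OC[C@H]3CCCN3)nc21`, differs from compound 3 by (pyrrolidin-2-yl)methoxy in place of (3-hydroxypropyl)amino on an aromatic carbon. No measured step touches this position or this kind of exchange, so no direction can be taken from the shown steps, and the expectation rests on compound 3 alone, whose value is 8800 nM. Compound 4 is therefore expected to give 7000 nM, within 1500 nM to 40000 nM, which means an expected step of a 1.3-fold lower number from compound 3 to compound 4 (0.10 log units; within the scatter).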

Compound 4, half-maximal inhibitory concentration: > 100000 nM
Compound 4 gave a limit, no number; the forecaster's own chance of this, stated with the estimate: 10%; middle value at least 14-fold (1.15 log units) away from the limit.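

Among these compounds, the aromatic carbon between two ring nitrogen atoms, which no earlier step touched, proves sensitive to a single exchange: (pyrrolidin-2-yl)methoxy in place of (3-hydroxypropyl)amino gives an at least 11-fold higher number from compound 3 to compound 4 (1.05 log units; beyond the scatter). Among the compounds shown here, the chain on the aromatic nitrogen is therefore not the only place where one change moves the read-out, and this exchange goes towards weaker inhibition. Compound 4 gives a limit and not a number, and it shares this with compound 2: the limit of > 100000 nM in this assay, at which 2 of the 4 values shown sit.

The exchange alters the linking atom, from nitrogen to oxygen, and the ring at the same time, so these compounds cannot tell which of the two matters. From the compounds shown here alone, it remains open whether a (pyrrolidin-2-yl)methylamino group, which keeps the ring but links through nitrogen, or a longer hydroxyalkylamino chain would stay close to compound 3 at 8800 nM.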